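Notes on the chain carried by the aromatic nitrogen

The compounds below may be only part of what the source reports. "The series", "measured", "known", "first", "only" and "open" are said of these compounds alone.

Measured in a functional assay on MSTO-211H cells (Homo sapiens) for inhibition, read by trypan blue exclusion, with a stated time of 72 h (a lower number here means a stronger inhibitor of growth, a higher number a weaker inhibitor of growth), so far:
compound 1 `Cc1c(-c2ccc(O)c(O)c2)n(CCCCOc2ccccc2)c2ccc(O)cc12`: 3400 nM
compound 2 `Cc1c(-c2ccc(O)cc2)n(CCCCOc2ccccc2)c2ccc(O)cc12`: 2900 nM

Compound 1 stands at the higher of the two numbers, and its nearest neighbour is compound 2, the step being a 1.2-fold lower number from compound 1 to compound 2 (0.07 log units; within the scatter). The two compounds are therefore indistinguishable within the scatter of this assay.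

The next compound, compound 3 `Cc1c(-c2ccc(O)c(O)c2)n(C)c2ccc(O)cc12`, alters compound 1 at a different place: hydrogen in place of 3-phenoxypropyl on a saturated chain carbon bound to an aromatic nitrogen. Within the data shown here, no measured step bears on this change. Among the measured compounds shown here, the one step available, from compound 1 to compound 2, concerns only a hydroxy on an aromatic carbon and stays within the scatter, so it offers no guidance on what loss of the 3-phenoxypropyl group does in this assay.

With nothing to anchor the prediction, the expectation rests on the size of the change alone: the whole 3-phenoxypropyl group, with its aromatic ring, leaves the shared core. A higher number for compound 3 is expected, the estimated step being a 2.4-fold higher number from compound 1 to compound 3 (0.37 log units; beyond the scatter). Compound 3 is estimated at 8000 nM, with a range from 2500 nM to 25000 nM.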

Compound 3, concentration for 50% growth inhibition: > 20000 nM
Compound 3 ended at the assay's limit; the forecaster's own chance of this, stated with the estimate: 20%; middle value at least 2.5-fold (0.39 log units) away from the limit.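

Among these compounds, the chain on the aromatic nitrogen is the first place where a change registers in this assay: hydrogen in place of 3-phenoxypropyl gives an at least 5.8-fold higher number from compound 1 to compound 3 (0.76 log units; beyond the scatter), whereas the only earlier step, a 1.2-fold lower number from compound 1 to compound 2 (0.07 log units; within the scatter), concerned a hydroxy on an aromatic carbon. Compound 3 stands at > 20000 nM, which is a limit of the assay and not a number: the limit of > 20000 nM in this assay, at which 1 of the 3 values shown sits. This single pair shows that growth inhibition at this level depends on the 3-phenoxypropyl group as a whole, but it removes the aromatic ring, the oxygen and the chain together and so cannot separate them.

Going by these compounds, it remains open which part of the 3-phenoxypropyl group carries the step, the six-membered aromatic ring or the saturated chain that holds it. Also open, on these data alone, is whether a longer chain, or a chain ending in an amine or a carboxylic acid in place of the phenoxy group, would keep the value of the parent compound or move it in either direction.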